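A few compounds are considered here, and "the series" means these few. Any claim that something is new, unique, unknown or untested is made for them only; others in the source may bear on it.

Among the measured compounds shown here, compound 3 `CCCCCCCCSc1nc(N)nc2c1ncn2/C=C1/CC1(CO)CO` is the one compound here whose result is a number rather than a limit: in an ADME assay on CCRF-HSB-2 cells (Homo sapiens) for cytotoxicity, with a stated time of 7 days (on this read-out lower numbers stand for higher toxicity in this test and higher numbers for lower toxicity in this test), compound 3 gives 60000 nM. Its two neighbours are known only through limits. In this assay compound 1 `CCCCCCCCOc1nc(N)nc2c1ncn2/C=C1/CC1(CO)CO` gives a limit of > 20000 nM. In this assay compound 2 `CCCCCOc1nc(N)nc2c1ncn2/C=C1/CC1(CO)CO` likewise gives a limit of > 20000 nM. Because of the limit of > 20000 nM in this assay, at which 2 of the 3 values shown sit, the step that the limit leaves unreadable from compound 1 to compound 3 cannot be read in size, and the same holds for a step that the limit leaves unreadable from compound 2 to compound 3 and for a step that the two limits leave unreadable from compound 1 to compound 2, which sits between two limits.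

Compound 4 `CSc1nc(N)nc2c1ncn2/C=C1/CC1(CO)CO` has not been measured in this assay. It differs from compound 3 in one place: hydrogen in place of heptyl on a saturated chain carbon bound to a sulfur. For the measured compounds named here, no measured step bears on this change with a readable size; the only step that also shortens a chain, a step that the two limits leave unreadable from compound 1 to compound 2, is unreadable, and the one number in the set lies where toxicity in this test is low. Compound 4 is therefore expected to give about 50000 nM, in the range 15000 nM to 200000 nM, with a real chance that only a limit is reported. The step of a 1.2-fold lower number from compound 3 to compound 4 (0.08 log units; within the scatter) is accordingly expected to stay within the usual scatter.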

Compound 4, half-maximal cytotoxic concentration: > 100000 nM
Compound 4 ended at the assay's limit; the forecaster's own chance of this, stated with the estimate: 60%; middle value at least 2.0-fold (0.30 log units) away from the limit.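

Compound 4 gives > 100000 nM in this assay, and this value is a limit of the assay, not a number. The change of octyl to methyl on the sulfur is an at least 1.6-fold higher number from compound 3 to compound 4 (0.22 log units; that floor lies within the scatter), so a real difference is not proven, but this much shorter chain brings no sign of toxicity in this test up to the concentrations reached. The steps that link compound 4 to compound 1 and compound 2 cannot be read in size because limits stand at both ends: the limit of > 100000 nM in this assay, at which 1 of the 4 values shown sits.

On these data alone, it stays open whether an oxygen or a sulfur on the aromatic carbon makes any difference to this read-out, and whether chain length matters at all, since the chains on the sulfur are known only as octyl and methyl. A butyl chain on the sulfur, or an amine in place of the whole sulfur-linked chain on the aromatic carbon, would add to this picture only if the result came out as a number rather than a limit.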